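Tert-butyl in place of methyl at the assay limit

This account rests on a few compounds, and the source may have more. Where it says the series, first, only, none or still open, it means among the compounds named here.

In a functional assay on CEM-SS cells (Homo sapiens) for cytotoxicity (on this read-out higher numbers stand for weaker inhibition and lower numbers for stronger inhibition), compound 3 (`Cc1ccc(Cn2c(Cl)nc3cc(Cl)c(Cl)cc32)cc1`) gives > 100000 nM, which is a limit and not a number. Compound 2 (`Clc1ccc(Cn2c(Cl)nc3cc(Cl)c(Cl)cc32)cc1`) gives > 100000 nM, again a limit. For the measured compounds named here, the series so far therefore shows (the limit of > 100000 nM in this assay, at which 2 of the 3 values shown sit). Going by the values given here, the one measured step is a step that the two limits leave unreadable from compound 2 to compound 3, so it offers no size to carry forward.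

Compound 4 (`CC(C)(C)c1ccc(Cn2c(Cl)nc3cc(Cl)c(Cl)cc32)cc1`) differs from compound 3 by tert-butyl in place of methyl on an aromatic carbon, para to a large group. Among the compounds with values here, compound 1 (`CC(C)(C)c1ccc(Cn2c(N)nc3cc(Cl)c(Cl)cc32)cc1`) carries the same tert-butyl group but differs from compound 4 elsewhere, and in this assay compound 1 gives 27000 nM, the only true number. On that single value, a modest move towards stronger inhibition is expected, although another limit reading remains quite possible. The estimated change is an at least 1.2-fold lower number from compound 3 to compound 4 (0.09 log units; that floor lies within the scatter). Compound 4 is expected at 80000 nM, with an estimated range of 30000 nM to 200000 nM.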

Compound 4, half-maximal inhibitory concentration: > 100000 nM
Compound 4 gave a limit, no number (the forecaster's own chance of this, stated with the estimate: 55%); at least 1.2-fold (0.09 log units) between middle value and limit.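

In this assay compound 4 gives > 100000 nM, which is a limit and not a number. Chloro, methyl and tert-butyl on this aromatic carbon all leave the series at the same ceiling, and the steps among compound 2, compound 3 and compound 4 cannot be read: the limit of > 100000 nM in this assay, at which 3 of the 4 values shown sit. For the compounds shown here, the one readable step is an at least 3.7-fold higher number from compound 1 to compound 4 (0.56 log units; beyond the scatter), for chloro in place of amino on an aromatic carbon, so tert-butyl alone does not bring a value under the limit, and the only true number belongs to the compound carrying amino.

Going by these compounds, how far compound 2, compound 3 and compound 4 lie past the limit stays open, and so does any order among them. Also open, on these data alone, is what a carboxylic acid or a methylamino group in place of the amino of compound 1 would give, and whether amino still yields a number with methyl in place of tert-butyl.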